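Methyl-to-hydrogen step on the aniline ring, second core

The compounds below may be only part of what the source reports. "The series", "measured", "known", "first", "only" and "open" are said of these compounds alone.

Compound 1 `COc1cc(OC)c2sc(-c3ccc(N/C=C\C(=O)c4ccc(OC)c(O)c4)c(C)c3)nc2c1` and compound 2 `COc1cc(OC)c2sc(-c3ccc(N/C=C\C(=O)c4ccc(OC)c(O)c4)cc3)nc2c1` share one core; compound 3 `COc1ccc2nc(-c3ccc(N/C=C\C(=O)c4cc(OC)c(OC)c(OC)c4Br)c(C)c3)sc2c1` and compound 4 `COc1ccc2nc(-c3ccc(N/C=C\C(=O)c4cc(OC)c(OC)c(OC)c4Br)cc3)sc2c1` share another. The difference between the two cores is not broken down here. In a functional assay on HeLa cells (Homo sapiens) for antiproliferative activity, read by sulforhodamine B assay, with a stated time of 48 h (a lower number here means a stronger inhibitor, a higher number a weaker inhibitor), compound 1 gives 16100 nM, and compound 2 gives 12100 nM. The change between them is hydrogen in place of methyl on an aromatic carbon and it made a 1.3-fold lower number from compound 1 to compound 2 (0.12 log units; within the scatter). In this assay compound 3 gives 13400 nM, a number that sits within the scatter of compound 2. Compound 4 is not yet measured; it differs from compound 3 by hydrogen in place of methyl on an aromatic carbon. This is the same kind of change as that from compound 1 to compound 2: in both the methyl is ortho to a large group, but in compound 3 the position is meta to a 6-methoxy-1,3-benzothiazol-2-yl group, whereas in compound 1 it is given only as meta to a large group. Because the measured step of a 1.3-fold lower number from compound 1 to compound 2 (0.12 log units; within the scatter) stayed within the scatter, a similar step, a 1.2-fold lower number from compound 3 to compound 4 (0.09 log units; within the scatter), is expected in this assay. The estimate for compound 4 in this assay is 11000 nM, expected to fall between 6000 nM and 22000 nM.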

Compound 4, half-maximal inhibitory concentration: 8020 nM
Estimate against measurement, compound 4: 1.4-fold (0.14 log units) above; low and high end bracket the measured number.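

In this assay, hydrogen in place of methyl on an aromatic carbon, ortho to a large group, gives a 1.7-fold lower number from compound 3 to compound 4 (0.22 log units; within the scatter), and the two cores do not differ in their response to this change: the same change on two cores in this assay, a 1.3-fold lower number (0.12 log units; within the scatter) from compound 1 to compound 2 and a 1.7-fold lower number (0.22 log units; within the scatter) from compound 3 to compound 4, 1.3-fold (0.10 log units) apart, within the scatter of two such steps

Within these two matched pairs, the change therefore carries from one core to the other with no detectable difference, and on neither core can the step be separated from the scatter of repeated measurements. This does not show that removing the methyl improves antiproliferative activity on either core, nor that the same agreement would hold on a third core or with a different substitution on the two cores shown.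

The compounds shown leave open whether another group at this position, such as ethyl, methoxy, chlorine or an amine, would give a step beyond the scatter on either core. They also leave open whether the agreement between the cores extends to any read-out other than this assay.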